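Dropping the Ester from an Aryl Urea

The compounds below may be only part of what the source reports. "The series", "measured", "known", "first", "only" and "open" are said of these compounds alone.

Three compounds built on a shared core were tested in a functional assay on WiDr cells (Homo sapiens) for inhibition; on this read-out lower numbers stand for stronger inhibition and higher numbers for weaker inhibition. Compound 1 `CCOC(=O)CNC(=O)N1CC1C#N` gives 33000 nM. Compound 3 `CCOC(=O)c1ccc(NC(=O)N2CC2C#N)cc1` gives 4200 nM. Of the two numbers recorded, compound 3 stands lowest, and its nearest neighbour, compound 1, sits a gap away that is beyond the usual scatter. Compound 2 `CC(C)(C)NC(=O)N1CC1C#N` reaches only a limit of the assay, > 300000 nM. For compound 2 this is the limit (the limit of > 300000 nM in this assay, at which 1 of the 3 values shown sits), and nothing more is said of it. Compound 4 `N#CC1CN1C(=O)Nc1ccccc1` has not yet been measured; it differs from compound 3 by hydrogen in place of ethoxycarbonyl on an aromatic carbon. Among the measured compounds shown here, no measured pair separated by one change exists, so the size of this step cannot be read from the data; the aryl urea and the two alkyl ureas differ in more than one place and only their values can be set side by side. The expected step is a 2.9-fold higher number from compound 3 to compound 4 (0.46 log units; beyond the scatter), a weakening somewhat beyond the scatter. Compound 4 is thus estimated at 12000 nM, within a range from 3000 nM to 50000 nM.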

Compound 4, half-maximal inhibitory concentration: 12000 nM
The estimate for compound 4 equals the measured number at the digits printed; the measured number falls inside the stated range.
By their numbers in this assay, from the lowest: compound 3; then compound 4; then compound 1. At a limit, above all of these: compound 2.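

Among the compounds shown here, replacing the ethoxycarbonyl with hydrogen on this aromatic carbon gives, in this assay, a 2.9-fold higher number from compound 3 to compound 4 (0.46 log units; beyond the scatter), the first single change whose size can be read. The step is modest but beyond the scatter, so the ester contributes to the read-out at this position, yet compound 4 still gives a measured number without it rather than reaching a limit of the assay. Nothing measured here accounts for the size of this step.

As far as these compounds go, whether a carboxylic acid, an amine or a methoxy group on this aromatic carbon would give a number nearer that of compound 3 or that of compound 4 remains open. Also open, from the compounds shown here alone, is whether the carbonyl or the ethyl part of the ester carries the difference, which a methyl ketone or a longer alkyl ester could separate.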